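The source may hold more compounds than are shown below. What is called first, only, known or untested is meant among the compounds shown, and "the series" means these compounds.

Working notes on the series in a functional assay on HL-60 cells (Homo sapiens) for cytotoxicity, read by MTT assay, with a stated time of 4 days; a lower number here means a stronger inhibitor, a higher number a weaker inhibitor.

Compound 1 `C=C1C[C@]23C[C@@]1(O)CC[C@H]2c1ccc(O)c(C)c1[C@@H]3Cn1cc(-c2ccccn2)nn1` carries a pyridin-2-yl on the five-membered ring and an additional hydroxyl on the core. In this assay compound 1 gives only a limit, > 20000 nM. Compound 2 `C=C1C[C@]23C[C@@]1(O)CC[C@@H]2c1cccc(C)c1[C@@H]3Cn1cc(-c2ccc(OC)cc2)nn1` carries a 4-methoxyphenyl on the five-membered ring and lacks that hydroxyl. In this assay compound 2 likewise gives only a limit, > 20000 nM. Going by the values given here, compound 2 thus stands where every value so far stands: the limit of > 20000 nM in this assay, at which 2 of the 2 values shown sit. Between compound 1 and compound 2 no number separates the two.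

Compound 3 `C=C1C[C@]23C[C@@]1(O)CC[C@@H]2c1cccc(C)c1[C@@H]3Cn1cc(-c2ccccn2)nn1` is the next member. The change from compound 2 is pyridin-2-yl in place of 4-methoxyphenyl on an aromatic carbon. Among the compounds with values here, no measured step exists between compounds that differ in one place, so the size of this step has no precedent. Compound 1 carries the same pyridin-2-yl and gives only a limit in this assay, > 20000 nM. For compound 3 the expected step that the limit leaves unreadable from compound 2 to compound 3 is none beyond the scatter. Compound 3 is therefore expected near 30000 nM, within 10000 nM to 100000 nM, most probably reported again only as a limit.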

Compound 3, half-maximal inhibitory concentration: > 20000 nM
Compound 3 ended at the assay's limit; the forecaster's own chance of this, stated with the estimate: 85%; the middle value is on the limit's open side.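

Compound 2 and compound 3 each give only a limit in this assay, so no step can be read between them: the limit of > 20000 nM in this assay, at which 3 of the 3 values shown sit.

The compounds shown leave open whether pyridin-2-yl, 4-methoxyphenyl or the additional hydroxyl on the core changes the cytotoxicity at all; none of them yet gives a number inside the range of this assay.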